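Aryl exchange at the chain end: compound 2 to compound 3

The source may hold more compounds than are shown below. What is called first, only, known or untested is meant among the compounds shown, and "the series" means these compounds.

Two members of the series carry a measurement in an assay on HEK293 cells for displacement of a labelled ligand from Melanocortin receptor 4 (Homo sapiens); a lower number here means a stronger inhibitor, a higher number a weaker inhibitor. Compound 1 `CCC(C)[C@H](N)c1cc(C(F)(F)F)ccc1N1CCN(C(=O)CCc2ccc(OC)c(OC)c2Cl)CC1` gives 2500 nM in this assay, and compound 2 `CC(C)C[C@H](N)c1cc(C(F)(F)F)ccc1N1CCN(C(=O)CCc2ccccc2Cl)CC1` gives 1700 nM. Compound 2 has the lower of the two numbers, yet its gap to compound 1 falls within the usual scatter, so the two compounds stand together rather than apart on this evidence. Compound 3 `CC(C)C[C@H](N)c1cc(C(F)(F)F)ccc1N1CCN(C(=O)CCc2cccc(C(F)(F)F)c2)CC1` has not yet been measured in this assay. It differs from compound 2 by 3-(trifluoromethyl)phenyl in place of 2-chlorophenyl on a saturated chain carbon, two bonds along the chain from a carbonyl carbon. Within the data shown here, no measured pair shows this exchange, so nothing among the known numbers says which way it turns. The step of a 1.2-fold higher number from compound 2 to compound 3 (0.07 log units; within the scatter) is expected to stay within the scatter, with no direction that the two numbers shown could back. Compound 3 is accordingly estimated at 2000 nM in this assay, with a range from 600 nM to 7000 nM.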

Compound 3, inhibition constant: 2200 nM
Compound 3: middle estimate off by 1.1-fold (0.04 log units), on the low side; measured number inside the range.
By their numbers in this assay, from the lowest: compounds 2, 3 and 1 (each within the scatter of the next).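

In this assay, among these compounds, replacing 2-chlorophenyl with 3-(trifluoromethyl)phenyl on the saturated chain carbon gives a 1.3-fold higher number from compound 2 to compound 3 (0.11 log units; within the scatter) and provides the first single-place comparison. At this position, the two aryl groups, with 7 and 10 heavy atoms, therefore cannot be told apart in this assay, even though the substituent differs in identity and in its place on the ring. Nothing available bears on the reason for this result.

This single exchange leaves open whether an amine or a carboxylic acid on the ring, a cyclohexyl group in place of the ring, or a longer chain before it would give a step beyond the scatter. Compound 1 differs from compound 2 in more than one place, so the contributions of its chain and aryl parts remain unseparated.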